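The compounds below may be only part of what the source reports. "The series", "measured", "known", "first", "only" and "open" are said of these compounds alone.

Measured compounds:
compound 1, `Clc1ccc2c(NCCCNc3nccc(N4CCCC4)n3)ccnc2c1`: 0.756
compound 2, `Clc1ccc2c(NCCCCCCCCNc3ccnc(Cl)n3)ccnc2c1`: 1.48

Of the compounds shown here, two have been measured in a physicochemical assay for lipophilicity, read by HPLC, in phosphate buffer, measured as octanol-water partition, with a stated time of 24 h, at pH 7.4; on this read-out lower numbers stand for lower lipophilicity and higher numbers for higher lipophilicity. Compound 1 stands lowest of the two numbers with 0.756; the nearest, compound 2, gives 1.48 in this assay, a value that lies higher by more than the usual scatter. No step between the two measured compounds is shown, since they differ in more than one place, so their two values are simply noted side by side.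

The step followed here leads from compound 1 to compound 3, `Clc1ccc2c(NCCCNc3nccc(N4CCNCC4)n3)ccnc2c1`, which has not yet been measured in this assay. The change is piperazin-1-yl in place of pyrrolidin-1-yl on an aromatic carbon.

For this change a step downward beyond the scatter is expected, a number 1.26 log units lower from compound 1 to compound 3 (beyond the scatter), resting on the value of compound 1, 0.756, as the starting point. Compound 3 is therefore estimated to give -0.5 in this assay, with a range from -1.3 to 0.3.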

Compound 3, distribution coefficient: 0.102
Compound 3: middle estimate off by 0.60 log units, on the low side; measured number inside the range.
By their numbers in this assay, from the lowest: compound 3; then compound 1; then compound 2.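

On the read-out of this assay the group on this aromatic carbon, next to the ring nitrogen, clearly matters: piperazin-1-yl in place of pyrrolidin-1-yl gives a number 0.65 log units lower from compound 1 to compound 3 (beyond the scatter) while the rest of the structure stays the same. Going by these compounds alone, the earlier values could not show this, as compound 1 and compound 2 differ in more than one place and could only be set side by side, so this is the first change at a single place that can be read. The entering ring is six-membered rather than five-membered and brings a second nitrogen and a hydrogen-bond donor, but nothing measured here bears on why the number moves.

A single step leaves open which of these differences carries the shift, and a comparison with piperidin-1-yl, morpholin-4-yl or 4-methylpiperazin-1-yl on the same carbon would begin to separate them. From the compounds shown here alone, it also remains open whether the same exchange would give a step of similar size on a compound with a longer chain between the two aromatic parts.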